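Methoxy added to the isopropoxy chain of compound 1

The source may hold more compounds than are shown below. What is called first, only, known or untested is meant among the compounds shown, and "the series" means these compounds.

In a physicochemical assay for solubility, in phosphate buffer, measured as kinetic solubility, with a stated time of 24 h, at pH 6.5 (on this read-out lower numbers stand for lower solubility and higher numbers for higher solubility), compound 1 (`CC(C)Oc1cc(Oc2cnc(C(=O)N(C)C)nc2)cc(-c2nccc(=O)[nH]2)c1`) gives 332000 nM as its measured value. Compound 3 (`CC(C)Oc1cc(Oc2cnc(C(=O)N(C)C)cn2)cc(-c2nccc(=O)[nH]2)c1`) gives 373000 nM and sits within the usual scatter of compound 1, so these two cannot be told apart. Compound 2 (`CC(C)Oc1cc(Oc2ccc(S(C)(=O)=O)cc2)cc(-c2ncc(Cl)c(=O)[nH]2)c1`) gives 24000 nM and lies lower than compound 1 by a gap beyond the scatter. These three compounds differ in more than one place, so no single structural change can be read from them.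

Compound 4 (`COC[C@H](C)Oc1cc(Oc2cnc(C(=O)N(C)C)nc2)cc(-c2nccc(=O)[nH]2)c1`) has not yet been measured. Its difference from compound 1 is methoxy in place of hydrogen on a saturated chain carbon, two bonds along the chain from an oxygen on an aromatic ring and amounts to methoxy in place of hydrogen on a saturated chain carbon, two bonds along the chain from an oxygen on an aromatic ring. Isopropoxy thus becomes 1-(methoxymethyl)ethoxy. For the measured compounds named here, no measured pair tests this change, so the expectation rests on compound 1 at 332000 nM as the starting point. The expected change in this assay is a 1.1-fold lower number from compound 1 to compound 4 (0.04 log units; within the scatter) and stays within the scatter, with no clear direction. The estimate for compound 4 is 300000 nM within an expected range from 110000 nM to 700000 nM for this measurement.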

Compound 4, solubility: 342000 nM
Beside the measured number, compound 4's estimate is 1.1-fold (0.06 log units) below it; the measured number falls inside the stated range.
By their numbers in this assay, from the lowest: compound 2; then compounds 1, 4 and 3 (each within the scatter of the next).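

In this assay, the change from isopropoxy to 1-(methoxymethyl)ethoxy gives a 1.0-fold higher number from compound 1 to compound 4 (0.01 log units; within the scatter). For the compounds shown here, this is the first comparison here in which only one place differs, and it shows that methoxy in place of hydrogen on this saturated chain carbon leaves compound 1 and compound 4 impossible to tell apart on this read-out. Nothing given here explains this result.

As far as these compounds go, it remains open whether other groups at this chain carbon, such as an amine, a carboxylic acid or a longer chain, would also stay within the scatter of compound 1. From the compounds shown here alone, it is equally open whether the same methoxy would give a similar result on the core of compound 2, whose number stands well apart from the others.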